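This account rests on a few compounds, and the source may have more. Where it says the series, first, only, none or still open, it means among the compounds named here.

In a functional assay on A549 cells (Homo sapiens) for antiproliferative activity, read by MTT assay, with a stated time of 72 h (a higher number here means a weaker inhibitor, a lower number a stronger inhibitor), compound 2 (`CCCNC(=O)c1cc(Oc2ccc(NC(=O)c3nn(-c4ccc(C)cc4)c(=O)cc3C)cc2F)ccn1`) gives 18000 nM. Compound 3 (`CCNC(=O)c1cc(Oc2ccc(NC(=O)c3nn(-c4ccccc4C)c(=O)cc3C)cc2)ccn1`) gives 34800 nM, which lies within the scatter of compound 2. Compound 1 (`CCNC(=O)c1cc(Oc2ccc(NC(=O)c3nn(-c4ccccc4OC(F)(F)F)c(=O)cc3C)cc2)ccn1`) gives 5280 nM, a number clearly lower than that of compound 2. So compound 2 sits with compound 3, at the weaker end of this small set.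

Compound 4 (`CCCNC(=O)c1cc(Oc2ccc(NC(=O)c3nn(-c4ccc(Br)cc4F)c(=O)cc3C)cc2F)ccn1`) differs from compound 2 in a single group, the aromatic ring on the ring nitrogen: 4-bromo-2-fluorophenyl in place of 4-methylphenyl on an aromatic nitrogen. Put simply, 4-bromo-2-fluorophenyl stands in place of 4-methylphenyl on an aromatic nitrogen.

For the measured compounds named here, only one measured step touches this same group: methyl in place of trifluoromethoxy gave a 6.6-fold higher number from compound 1 to compound 3 (0.82 log units; beyond the scatter). Read backwards, that step shows a methyl leaving the group and a fluorine-bearing substituent entering, with a lower number as the result. It is only a loose guide, since trifluoromethoxy is neither a lone fluorine nor a bromine, and a single step cannot establish a pattern.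

A smaller move in the same direction therefore seems the reasonable expectation in this assay. The expected change is a 2.3-fold lower number from compound 2 to compound 4 (0.35 log units; beyond the scatter). For compound 4 the estimated value is 8000 nM, with an expected range from 2500 nM to 22000 nM.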

Compound 4, half-maximal inhibitory concentration: 235000 nM
Beside the measured number, compound 4's estimate is 29-fold (1.47 log units) below it, and the stated range ends below it.
By their numbers in this assay, from the lowest: compound 1; then compounds 2 and 3 (each within the scatter of the next); then compound 4.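

In this assay, placing 4-bromo-2-fluorophenyl where 4-methylphenyl stood on the aromatic nitrogen gives a 13-fold higher number from compound 2 to compound 4 (1.12 log units; beyond the scatter) and is the largest step seen so far, so the group at this position can shift the number a long way in the direction of a weaker inhibitor. For the compounds shown here, the only earlier step at this ring paired a fluorine-bearing group, the trifluoromethoxy of compound 1, with the lower number, whereas compound 4 carries fluorine and bromine and has the highest number of the set, so halogen-containing groups here do not share a single direction, and compound 4 stands against any such rule drawn from compound 1. Nothing among the data offers a measured reason for this rise.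

The change also swaps methyl for bromine and adds a fluorine in one move, so the compounds shown cannot say which of the two accounts for the step. A 4-bromophenyl or a 2-fluorophenyl group on the same nitrogen would pull the two apart, and an amine or a carboxylic acid on this ring would show how far the number moves with a very different kind of group.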